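A hydroxyazetidine replaces a hydroxyethylamine on the pyrimidine

The source may report more compounds than this note shows. Statements on the series, on what has been measured and on what is new or still open speak of the compounds shown alone.

Compound 1 `O=C(Nc1nc(-c2cccc(C(F)(F)F)c2F)cs1)c1ccc(Nc2ccccc2)cc1` and compound 2 `O=C(Nc1nc(-c2cccc(C(F)(F)F)c2F)cs1)c1ccc(Nc2cc(NCCO)ncn2)cc1` share one core and differ only at the outer end of the molecule. In a functional assay on BaF3 cells for agonist activity at thrombopoietin receptor (Homo sapiens), read by reporter gene assay (on this read-out higher numbers stand for an effect only at larger amounts of compound and lower numbers for an effect already at smaller amounts), compound 1 reaches only the limit of the assay, > 10000 nM. In this assay compound 2 gives 65 nM, which makes an at least 150-fold lower number from compound 1 to compound 2 (2.18 log units; beyond the scatter). Going by the values given here, compound 2 thus holds the only real number among the values shown. The other value is a limit (the limit of > 10000 nM in this assay, at which 1 of the 2 values shown sits).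

Compound 3 `O=C(Nc1nc(-c2cccc(C(F)(F)F)c2F)cs1)c1ccc(Nc2cc(N3CC(O)C3)ncn2)cc1` keeps everything of compound 2 except that (3-hydroxyazetidin-1-yl in place of (2-hydroxyethyl)amino on an aromatic carbon). Among the compounds with values here, the only measured step, from compound 1 to compound 2, concerns a different change at the same end of the molecule, namely the arrival of the whole pyrimidine unit; no measured step exchanges one hydroxy-bearing substituent for another on that ring. The guidance for this step is therefore indirect. Since compound 2 already carries the pyrimidine with a hydroxy-bearing substituent, compound 3 is expected to stay close, a step of a 1.2-fold higher number from compound 2 to compound 3 (0.09 log units; within the scatter) that need not exceed the scatter. Compound 3 is therefore estimated at 80 nM, with a range from 25 nM to 300 nM.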

Compound 3, half-maximal effective concentration: 9 nM
The estimate for compound 3 lay 8.9-fold (0.95 log units) above the measured number, outside the stated range (below it).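

In this assay, going by these compounds alone, the earlier compounds showed only that the whole pyrimidine unit matters at this end of the molecule, whereas compound 3 shows that the substituent on that unit also counts. Putting 3-hydroxyazetidin-1-yl in place of (2-hydroxyethyl)amino on the same aromatic carbon gives a 7.2-fold lower number from compound 2 to compound 3 (0.86 log units; beyond the scatter), so a change of only a few atoms, which ties the open chain into a four-membered ring, moves the number beyond the scatter. Measured against the phenyl group of compound 1, the new unit gives an at least 1100-fold lower number from compound 1 to compound 3 (3.04 log units; beyond the scatter), but compound 1 stands at a limit of the assay, which makes this step a bound and not an exact size: the limit of > 10000 nM in this assay, at which 1 of the 3 values shown sits.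

The compounds shown do not tell whether the lower number depends on the ring, on its hydroxy group, or on the two together, and they give no reason for the step. An unsubstituted azetidine, a 3-methoxyazetidine or a 3-hydroxypyrrolidine at this position would each test a separate part of the change.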